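This account rests on a few compounds, and the source may have more. Where it says the series, first, only, none or still open, it means among the compounds named here.

Compound 1 `O=C(Nc1ccc(-c2noc(-c3cccc(NS(=O)(=O)c4ccccc4)c3)n2)c(Cl)c1)c1cccnc1`: in a functional assay on MDA-MB-231 cells (Homo sapiens) for antiproliferative activity, read by MTT assay, with a stated time of 72 h (on this read-out higher numbers stand for weaker inhibition and lower numbers for stronger inhibition), compound 1 reaches only the assay limit of > 10000 nM.
Compound 2 `NS(=O)(=O)c1ccc(S(=O)(=O)Nc2cccc(-c3nc(-c4ccc(NC(=O)c5cccnc5)cc4Cl)no3)c2)cc1`: in this assay compound 2 likewise reaches only the assay limit of > 10000 nM.
Compound 3 `CC(=O)Nc1ccc(S(=O)(=O)Nc2cccc(-c3nc(-c4ccc(NC(=O)c5cccnc5)cc4Cl)no3)c2)cc1`: in this assay compound 3 gives 2500 nM.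

Compound 3 is thus the only one of the three with a measured number; the other two sit at a limit, as the limit of > 10000 nM in this assay, at which 2 of the 3 values shown sit, records. The next compound, compound 4 `CCN(CC)C(=O)Nc1ccc(S(=O)(=O)Nc2cccc(-c3nc(-c4ccc(NC(=O)c5cccnc5)cc4Cl)no3)c2)cc1`, differs from compound 3 by diethylamino in place of methyl on a carbonyl carbon.

Among the compounds with values here, two measured steps touch the same part of the structure: an at least 4.0-fold lower number from compound 1 to compound 3 (0.60 log units; beyond the scatter) and an at least 4.0-fold lower number from compound 2 to compound 3 (0.60 log units; beyond the scatter). Both show that the acetamido group brings the number into the readable range. Within the data shown here, neither step, however, alters the carbonyl substituent itself, so there is no measured step for the exchange of methyl for diethylamino. Among the measured compounds shown here, the only guidance is that the amide-type nitrogen is kept in compound 4, and the step from compound 3 to compound 4 is therefore expected to stay within the scatter in this assay, as no change at the digits printed from compound 3 to compound 4 (within the scatter).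

Compound 4 is accordingly estimated to give 2500 nM in this assay, with a likely range from 800 nM to 8000 nM.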

Compound 4, half-maximal inhibitory concentration: 8700 nM
The estimate for compound 4 lay 3.5-fold (0.54 log units) below the measured number, outside the stated range (above it).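

In this assay, within the data shown here, the earlier steps showed only that an acetamido group in place of hydrogen or sulfamoyl brought the number into the readable range, whereas the exchange of methyl for diethylamino on the carbonyl carbon gives a 3.5-fold higher number from compound 3 to compound 4 (0.54 log units; beyond the scatter). What sits on this carbonyl carbon therefore affects the number in its own right, and keeping the amide-type nitrogen does not by itself hold the value of the acetamido compound. The gain over the two earlier compounds is no longer secure, with an at least 1.1-fold lower number from compound 2 to compound 4 (0.06 log units; that floor lies within the scatter) and an at least 1.1-fold lower number from compound 1 to compound 4 (0.06 log units; that floor lies within the scatter), as both floors lie within the scatter and both steps start from a limit: the limit of > 10000 nM in this assay, at which 2 of the 4 values shown sit.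

Only methyl and diethylamino are shown on this carbonyl carbon, so it stays open whether the higher number goes with the added nitrogen or with the ethyl chains. An ethyl or propyl chain on the carbonyl carbon, a dimethylamino group or a morpholine ring could help separate these two possibilities.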